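From 4-fluorophenyl to 3,5-dimethoxyphenyl: an expected step

The source may report more compounds than this note shows. Statements on the series, on what has been measured and on what is new or still open speak of the compounds shown alone.

Measured compounds:
compound 1, `COc1ccc(Nc2cc(Nc3ccc(Oc4ccncc4-c4cccnc4)c(F)c3)ncn2)cc1`: 2140 nM
compound 2, `Fc1ccc(Nc2cc(Nc3ccc(Oc4ccncc4-c4cccnc4)c(F)c3)ncn2)cc1`: 710 nM

In a functional assay on A549 cells (Homo sapiens) for cytotoxicity, read by MTT assay, with a stated time of 72 h (a lower number here means a stronger inhibitor, a higher number a weaker inhibitor), compound 1 gives 2140 nM, and compound 2 gives 710 nM. Among the measured compounds shown here, of the two numbers, compound 2 has the lower; the only step between them, a 3.0-fold lower number from compound 1 to compound 2 (0.48 log units; beyond the scatter), is beyond the scatter.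

Compound 3, `COc1cc(Nc2cc(Nc3ccc(Oc4ccncc4-c4cccnc4)c(F)c3)ncn2)cc(OC)c1`, has not been measured. It differs from compound 2 in one place: 3,5-dimethoxyphenyl in place of 4-fluorophenyl on a nitrogen on an aromatic ring. For the measured compounds named here, the single measured step bears on this change only in part. Going back from fluoro to methoxy, the reverse of a 3.0-fold lower number from compound 1 to compound 2 (0.48 log units; beyond the scatter), raised the number by a modest amount; compound 3 carries two methoxy groups and no fluoro, so a number higher than that of compound 2, near or above that of compound 1, is the expectation. The data contain no direct test of a 3,5-dimethoxyphenyl group, so the size is uncertain. For compound 3 the expected step is a 3.5-fold higher number from compound 2 to compound 3 (0.55 log units; beyond the scatter), in this assay. Compound 3 is therefore estimated at 2500 nM, with a range from 900 nM to 7000 nM.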

Compound 3, half-maximal inhibitory concentration: 560 nM
Estimate against measurement, compound 3: 4.5-fold (0.65 log units) above, and the stated range ends above it.
By their numbers in this assay, from the lowest: compounds 3 and 2 (each within the scatter of the next); then compound 1.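

In this assay, replacing the 4-fluorophenyl on the nitrogen with a 3,5-dimethoxyphenyl gives a 1.3-fold lower number from compound 2 to compound 3 (0.10 log units; within the scatter), so this larger group with two methoxy groups cannot be told apart from the 4-fluorophenyl here. Methoxy groups on this ring therefore do not in themselves set compound 1 apart: changing its 4-methoxyphenyl to the 3,5-dimethoxyphenyl gives a 3.8-fold lower number from compound 1 to compound 3 (0.58 log units; beyond the scatter), and among these three, compound 1, whose steps to the other two both lie beyond the scatter, is the weakest. Nothing available accounts for why the 4-methoxyphenyl and the 3,5-dimethoxyphenyl part in this way.

On these data alone, it remains open whether the number or the placement of the methoxy groups matters, a question that a 3-methoxyphenyl or a 3,5-difluorophenyl on the same nitrogen would bear on directly. How far this tolerance extends also remains open, since a ring carrying a dimethylamino group, a carboxylic acid or a longer alkoxy chain such as butoxy is not among the compounds shown.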